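A Shared Tail Added to Two Different Cores

This account rests on a few compounds, and the source may have more. Where it says the series, first, only, none or still open, it means among the compounds named here.

Measured so far:
Compound 1 `NCCNC(=O)c1c(O)c2ccccc2n(-c2ccccc2)c1=O`: 7.9%
Compound 2 `Cn1c(=O)c(C(=O)NCCCCCCN)c(O)c2ccccc21`: 21.9%
Compound 3 `O=C(CCCCC1CCSS1)NCCNC(=O)c1c(O)c2ccccc2n(-c2ccccc2)c1=O`: 14.1%

All three compounds were tested in a functional assay, with a stated time of 60 min, tested at 0.5 mM; on this read-out higher numbers stand for a stronger effect at the one concentration tested and lower numbers for a weaker effect. Compound 1 gives 7.9%. Compound 3 differs from compound 1 by a group of 11 heavy atoms (8 carbon, 1 oxygen, 2 sulfur; one five-membered non-aromatic ring with 2 hetero atoms) in place of a hydrogen atom, on an amine nitrogen. In this assay compound 3 gives 14.1%. The step of a number 6.2 percentage points higher from compound 1 to compound 3 (within the scatter) is small and lies within the usual scatter of this kind of measurement, so the added group did not clearly move the read-out on this core.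

Compound 2 carries a different core; how its core differs from that of compound 1 is not broken down here. In this assay compound 2 gives 21.9%, the highest of the three numbers, though its gap to compound 3 lies within the scatter and only its gap to compound 1 lies beyond it.

Compound 4 `Cn1c(=O)c(C(=O)NCCCCCCNC(=O)CCCCC2CCSS2)c(O)c2ccccc21` has not yet been measured. It relates to compound 2 as compound 3 relates to compound 1: the change is a group of 11 heavy atoms (8 carbon, 1 oxygen, 2 sulfur; one five-membered non-aromatic ring with 2 hetero atoms) in place of a hydrogen atom, on an amine nitrogen, the same change at the same kind of place. For the measured compounds named here, the expected step of a number 6.1 percentage points higher from compound 2 to compound 4 (within the scatter) is kept close to the measured step of a number 6.2 percentage points higher from compound 1 to compound 3 (within the scatter), since that is the only example of this change available. On that basis compound 4 is expected to give about 28% in this assay, most likely between 12% and 45%.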

Compound 4, a percentage reported as activity, at one concentration (the size of the read-out at that concentration, not a potency): 38.8%
Beside the measured number, compound 4's estimate is 10.8 percentage points below it; the measured number falls inside the stated range.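

In this assay, placing the group of 11 heavy atoms on the amine nitrogen gives a number 16.9 percentage points higher from compound 2 to compound 4 (beyond the scatter), so on this core the change clearly raises the read-out. Set beside the earlier example, the two steps point the same way and their sizes cannot be told apart: the same change on two cores in this assay, a number 6.2 percentage points higher (within the scatter) from compound 1 to compound 3 and a number 16.9 percentage points higher (beyond the scatter) from compound 2 to compound 4, 10.7 percentage points apart, within the scatter of two such steps. For the compounds shown here, this suggests that the change can be carried from one core to the other with a broadly similar result, but it rests on only two pairs, one of which has a step within the scatter, so it does not show that the steps are equal, that one core responds more strongly, or that the same would hold on a third core.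

The compounds shown leave open which part of the added group matters, for example whether a small acetyl group or a plain saturated chain on the same amine nitrogen would raise the read-out as well, or whether the five-membered non-aromatic ring is needed. They also leave open how a longer chain or a carboxylic acid at this place would behave, and, with only one concentration tested, how potency changes across these compounds.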